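Swapping the aryl group on the triazole nitrogen

The source may report more compounds than this note shows. Statements on the series, on what has been measured and on what is new or still open speak of the compounds shown alone.

Measured compounds in a functional assay on PC-12 cells (Rattus norvegicus) for cytotoxicity, read by MTT assay, with stated times of 2 h and 24 h, tested at 10 uM; a lower number here means a weaker effect, a higher number a stronger effect of the compound at the concentration tested:
- compound 1 `CCc1ccc(-n2nc(-c3ccc(C(F)(F)F)cc3O)nc2-c2ccccc2O)cc1` gives 107%
- compound 2 `CC(C)(C)c1ccc(-n2nc(-c3ccc(C(F)(F)F)cc3O)nc2-c2ccccc2O)cc1` gives 81.1%
- compound 3 `COc1ccc(-n2nc(-c3ccc(C(F)(F)F)cc3O)nc2-c2ccccc2O)cc1` gives 98.9%

Compound 1 has the highest number of the three. Compound 3 lies closest to it, and the step of a number 8.1 percentage points lower from compound 1 to compound 3 (within the scatter) stays within the scatter, so the two cannot be ranked. Compound 2 lies furthest away, with the step of a number 25.9 percentage points lower from compound 1 to compound 2 (beyond the scatter) beyond the scatter, and the step of a number 17.8 percentage points higher from compound 2 to compound 3 (beyond the scatter) is also beyond it.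

Compound 4 `COc1ccccc1-n1nc(-c2ccc(C(F)(F)F)cc2O)nc1-c1ccccc1O` has not been measured. It differs from compound 1 by 2-methoxyphenyl in place of 4-ethylphenyl on an aromatic nitrogen. The most relevant measured step is the one with methoxy in place of ethyl on an aromatic carbon, a number 8.1 percentage points lower from compound 1 to compound 3 (within the scatter), which was within the scatter. The group entering compound 4 is a 2-methoxyphenyl rather than a 4-methoxyphenyl, so that step is only a partial guide. Still, with a methoxy again replacing an ethyl, a step from compound 1 to compound 4 of about a number 7 percentage points lower from compound 1 to compound 4 (within the scatter) is expected, that is, no change beyond the scatter. Compound 4 is therefore estimated at 100%, within a range from 80% to 115%.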

Compound 4, a percentage reported as activity, at one concentration (the size of the read-out at that concentration, not a potency): 96.2%
Compound 4: middle estimate off by 3.8 percentage points, on the high side; low and high end bracket the measured number.
By their numbers in this assay, from the lowest: compound 2; then compounds 4, 3 and 1 (each within the scatter of the next, the first and the last beyond it).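

In this assay, the place of the methoxy on this aryl group makes no readable difference, with 2-methoxyphenyl in place of 4-methoxyphenyl giving a number 2.7 percentage points lower from compound 3 to compound 4 (within the scatter). Set against the other two groups, 2-methoxyphenyl gives a number 10.8 percentage points lower from compound 1 to compound 4 (beyond the scatter) and a number 15.1 percentage points higher from compound 2 to compound 4 (beyond the scatter), so the 4-(tert-butyl)phenyl group of compound 2 remains the one clearly apart from the other three, while compound 4 separates from compound 1 by a modest step. Nothing at hand explains why these aryl groups differ or match.

The compounds shown leave open how an aryl group carrying an amine or a carboxylic acid would read at this aromatic nitrogen. They also leave open what a longer alkyl chain in place of the whole aryl group would do.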